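This account rests on a few compounds, and the source may have more. Where it says the series, first, only, none or still open, it means among the compounds named here.

Measured set in a functional assay on MCF7 cells (Homo sapiens) for antiproliferative activity; on this read-out lower numbers stand for stronger inhibition and higher numbers for weaker inhibition:
compound 1 `COc1cc(Cc2nc3c(N)ncnc3n2CCCC(C)C)cc(OC)c1OC`, 69200 nM
compound 2 `CCCCCn1c(Cc2cc(OC)c(OC)c(OC)c2)nc2c(N)nc(F)nc21`, 36300 nM
compound 3 `CC#CCCn1c(Cc2cc(OC)c(OC)c(OC)c2)nc2c(N)nc(F)nc21`, 37200 nM

Compound 1 shows the highest of the three numbers, but its gaps to compound 3 and to compound 2 both fall within the scatter, so no order among them is claimed. Compound 4 `COc1cc(Cc2nc3c(N)ncnc3n2CC2(C)CC2)cc(OC)c1OC` differs from compound 1 in one place: 1-methylcyclopropyl in place of isopentyl on a saturated chain carbon bound to an aromatic nitrogen. Within the data shown here, the single measured step, a 1.0-fold higher number from compound 2 to compound 3 (0.01 log units; within the scatter), also alters the chain on the aromatic nitrogen, though at a different carbon and on a different core, and it stays within the scatter. Nothing measured separates isopentyl from a ring of this kind at this chain carbon. The expected step is a 1.2-fold lower number from compound 1 to compound 4 (0.06 log units; within the scatter), no change beyond the scatter. Compound 4 is estimated at 60000 nM, within 20000 nM to 180000 nM.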

Compound 4, half-maximal inhibitory concentration: 112000 nM
Estimate against measurement, compound 4: 1.9-fold (0.27 log units) below; the range from low to high includes it.
By their numbers in this assay, from the lowest: compounds 2, 3, 1 and 4 (each within the scatter of the next, the first and the last beyond it).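

Replacing isopentyl with 1-methylcyclopropyl on a saturated chain carbon bound to an aromatic nitrogen gives a 1.6-fold higher number from compound 1 to compound 4 (0.21 log units; within the scatter), so this assay does not tell this open chain from this carbon ring at this place. With a 1.0-fold higher number from compound 2 to compound 3 (0.01 log units; within the scatter) on the other core, both chain changes read so far stay within the scatter. On these data alone, whether an amine or a carboxylic acid on this chain would move the number beyond the scatter remains open, as does whether 1-methylcyclopropyl behaves alike on the core of compound 2. No evidence bears on this result.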